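This account rests on a few compounds, and the source may have more. Where it says the series, first, only, none or still open, it means among the compounds named here.

Measured in a functional assay on A-375 cells (Homo sapiens) for antiproliferative activity; a lower number here means a stronger inhibitor, a higher number a weaker inhibitor:
compound 1 `O=C(Nc1ccc(-c2cscn2)cc1)C1CN(Cc2ccc(F)c(F)c2)C1`: > 20000 nM (a limit of the assay)
compound 2 `O=C(Nc1ccc(-c2cscn2)cc1)C1CCCN(Cc2ccccc2F)C1`: 4000 nM

For the measured compounds named here, compound 2, at 4000 nM, carries the only numerical value so far. The entry for compound 1 is a limit and not a number.

Next in the series is compound 3 `O=C(Nc1ccc(-c2cscn2)cc1)C1CCCN(Cc2cccc(C(F)(F)F)c2)C1`, with this change: 3-(trifluoromethyl)phenyl in place of 2-fluorophenyl on a saturated chain carbon bound to an amine nitrogen in a ring. In words, 3-(trifluoromethyl)phenyl replaces 2-fluorophenyl on a saturated chain carbon bound to an amine nitrogen in a ring.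

Going by the values given here, no single-place step has been measured. In this assay, the estimated 1.1-fold lower number from compound 2 to compound 3 (0.06 log units; within the scatter) is expected to stay within the scatter, with no firm direction. Compound 3 is expected at 3500 nM, with an estimated range of 1300 nM to 11000 nM.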

Compound 3, half-maximal inhibitory concentration: > 20000 nM
Compound 3: no number, only a limit; the forecaster's own chance of this, stated with the estimate: 15%; middle value at least 5.7-fold (0.75 log units) away from the limit.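

In this assay, the group on the saturated chain carbon bound to an amine nitrogen in a ring turns out to matter: 3-(trifluoromethyl)phenyl in place of 2-fluorophenyl gives an at least 5.0-fold higher number from compound 2 to compound 3 (0.69 log units; beyond the scatter). From the compounds shown here alone, for compound 3 the entry is a limit of the assay and not a number, so the true size of this step stays unknown. Compound 2 therefore still carries the only number, and the step is bounded by that limit: the limit of > 20000 nM in this assay, at which 2 of the 3 values shown sit.

The compounds shown leave open whether the trifluoromethyl group or its place on the phenyl ring drives the change. A 3-fluorophenyl or a 2-(trifluoromethyl)phenyl group at this place would separate the two.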